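Benzyloxy for diethylamino on a carbonyl carbon

A few compounds are considered here, and "the series" means these few. Any claim that something is new, unique, unknown or untested is made for them only; others in the source may bear on it.

Of the compounds shown here, three have so far been read in a functional assay on T47D cells (Homo sapiens) for cytotoxicity, read by colorimetric assay and MTT assay; on this read-out lower numbers stand for stronger inhibition and higher numbers for weaker inhibition. Compound 1 (`COc1cc(OC)c2cc(-c3ccccc3)c(O)nc2c1`) gives 10000 nM. Compound 2 (`COc1cc(OC)c2cc(-c3ccc(OCc4ccccc4)cc3)c(O)nc2c1`) gives 10000 nM. Compound 3 (`CCN(CC)C(=O)Cn1c(=O)c(-c2ccc(OC)cc2)cc2c(OC)cc(OC)cc21`), which carries a diethylcarbamoyl group, gives 10000 nM, so it stands level with the other two, and the numbers do not separate it from them.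

Compound 4 (`COc1ccc(-c2cc3c(OC)cc(OC)cc3n(CC(=O)OCc3ccccc3)c2=O)cc1`) differs from compound 3 in one place: benzyloxy in place of diethylamino on a carbonyl carbon. Benzyloxy takes the place of diethylamino on a carbonyl carbon, turning diethylcarbamoyl into benzyloxycarbonyl.

Going by the values given here, only one measured step offers any guidance. It also brings in benzyloxy, though in place of hydrogen on an aromatic carbon, and it reads no change at the digits printed from compound 1 to compound 2 (within the scatter). That change sits elsewhere on the structure, so it bears on the present one only indirectly. Among the compounds with values here, no measured pair varies the diethylamino group itself, and no compound so far has moved away from the others. The expectation in this assay is therefore for no step beyond the scatter, in either direction. The estimated step is no change at the digits printed from compound 3 to compound 4 (within the scatter). For compound 4 the expected value is 10000 nM, with an estimated range from 4000 nM to 20000 nM.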

Compound 4, half-maximal inhibitory concentration: 10000 nM
The estimate for compound 4 equals the measured number at the digits printed; the range from low to high includes it.
By their numbers in this assay, from the lowest: compounds 1, 2, 3 and 4 (each within the scatter of the next).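

In this assay, going by these compounds alone, benzyloxy in place of diethylamino on a carbonyl carbon reads as no change at the digits printed from compound 3 to compound 4 (within the scatter), the only measured step that varies this position. Turning diethylcarbamoyl into benzyloxycarbonyl brings in a six-membered aromatic ring of carbon only and more heavy atoms, yet compound 4 stays at 10000 nM and does not separate from the other compounds. Benzyloxy has now been placed at two different sites, the other being an aromatic carbon with no change at the digits printed from compound 1 to compound 2 (within the scatter), and neither step moves the reading in this assay; nothing in hand explains this flat result.

All four compounds read alike, so these data cannot show whether the group on this carbonyl carbon matters at all in this assay. As far as these compounds go, it remains open whether a free carboxylic acid, a morpholine amide or a longer chain at this place would separate from compound 3 and compound 4, and whether any variation of the shared core would give a reading different from theirs.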